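Solubility across the step to compound 4

This account rests on a few compounds, and the source may have more. Where it says the series, first, only, none or still open, it means among the compounds named here.

Of the compounds shown here, three sharing one core have been measured in a physicochemical assay for solubility, read by HPLC, using the shake flask method, in phosphate buffer, with a stated time of 20 h, at pH 6.5; a higher number here means a more soluble compound, a lower number a less soluble compound. Compound 1 `CN1CCN(C2CCN(c3nccc4[nH]c(-c5cccc(OC(F)(F)F)c5)nc34)CC2)CC1` gives 190000 nM, compound 2 `CN1CCN(C2CCN(c3nccc4[nH]c(-c5ccc(F)c(C(F)(F)F)c5)nc34)CC2)CC1` gives 195000 nM, and compound 3 `CN1CCN(C2CCN(c3nccc4[nH]c(C5CCCC5)nc34)CC2)CC1` gives 170000 nM. The measured steps show no separation: a 1.0-fold higher number from compound 1 to compound 2 (0.01 log units; within the scatter), a 1.1-fold lower number from compound 2 to compound 3 (0.06 log units; within the scatter) and a 1.1-fold lower number from compound 1 to compound 3 (0.05 log units; within the scatter). Compound 2 therefore stands level with the other two.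

Compound 4 `CN1CCN(CC2CCN(c3nccc4[nH]c(-c5ccc(F)c(C(F)(F)F)c5)nc34)CC2)CC1` keeps the 4-fluoro-3-(trifluoromethyl)phenyl of compound 2 but carries (4-methylpiperazin-1-yl)methyl in place of 4-methylpiperazin-1-yl on a saturated ring carbon. Within the data shown here, no measured step touches this place, since all three exchange the group on an aromatic carbon. Among the measured compounds shown here, they bear on the change only indirectly, and they offer no precedent for a large movement in this set. Nothing measured points to a direction, so no shift beyond the scatter is expected in this assay. The expected change is a 1.1-fold lower number from compound 2 to compound 4 (0.03 log units; within the scatter). For compound 4 the estimated value is 180000 nM, with an expected range from 100000 nM to 260000 nM.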

Compound 4, solubility: 165000 nM
Beside the measured number, compound 4's estimate is 1.1-fold (0.04 log units) above it; the range from low to high includes it.
By their numbers in this assay, from the lowest: compounds 4, 3, 1 and 2 (each within the scatter of the next).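

In this assay, among these compounds, the first step at this saturated ring carbon reads a 1.2-fold lower number from compound 2 to compound 4 (0.07 log units; within the scatter), so (4-methylpiperazin-1-yl)methyl and 4-methylpiperazin-1-yl stand level on the 4-fluoro-3-(trifluoromethyl)phenyl compounds. Among the compounds shown here, the earlier steps all concerned the group on an aromatic carbon, so this is the first reading to show that the number can also hold at this second place when the group there is exchanged. No measured information accounts for this result, and the step itself gives no reason for it.

The compounds shown leave open whether the same level reading would hold with the cyclopentyl of compound 3 or the 3-(trifluoromethoxy)phenyl of compound 1 on the shared core. They also leave open what a carboxylic acid, a morpholine or a longer chain bearing the 4-methylpiperazin-1-yl would give on this saturated ring carbon.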